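Replacing a benzothiophenyl group with vinyl in compound 3

The source may hold more compounds than are shown below. What is called first, only, known or untested is meant among the compounds shown, and "the series" means these compounds.

In a functional assay on MGC-803 cells (Homo sapiens) for inhibition, read by MTT assay, with a stated time of 72 h (a lower number here means a stronger inhibitor, a higher number a weaker inhibitor), compound 2 (`Cc1cc(N2CC[C@@H](C)[C@@H](N(C)c3ncnc4[nH]ccc34)C2)n2nc(SCc3csc4ccc(Cl)cc34)nc2n1`) gives > 100000 nM, which is a limit of the assay and not a number. Compound 2 thus stands at the limit of > 100000 nM in this assay, at which 1 of the 2 values shown sits. It carries 5-chloro-1-benzothiophen-3-yl where compound 1 (`Cc1cc(N2CC[C@@H](C)[C@@H](N(C)c3ncnc4[nH]ccc34)C2)n2nc(SCC3CC3)nc2n1`) has cyclopropyl, and compound 1 gives 9540 nM. Going by the values given here, the only measured step that bears on the next change is an at least 10-fold higher number from compound 1 to compound 2 (1.02 log units; beyond the scatter), a large move towards weaker inhibition.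

Compound 3 (`C=CCSc1nc2nc(C)cc(N3CC[C@@H](C)[C@@H](N(C)c4ncnc5[nH]ccc45)C3)n2n1`) gives up the benzothiophenyl group: vinyl in place of 5-chloro-1-benzothiophen-3-yl on a saturated chain carbon bound to a sulfur. The same difference reads as allylsulfanyl in place of ((5-chloro-1-benzothiophen-3-yl)methyl)sulfanyl. Among the compounds with values here, with compound 1 at 9540 nM as the sole measured number, a large move to a lower number in this assay is expected, back into the region of compound 1. A single step is a thin guide, so the size remains uncertain. The expected change is an at least 8.3-fold lower number from compound 2 to compound 3 (0.92 log units; beyond the scatter), towards stronger inhibition. For compound 3 the estimated value is 12000 nM, with an expected range of 4000 nM to 40000 nM.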

Compound 3, half-maximal inhibitory concentration: 32600 nM
The estimate for compound 3 lay 2.7-fold (0.43 log units) below the measured number, and the stated range covers the measured number.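

In this assay, going by these compounds, the step to the allylsulfanyl group, an at least 3.0-fold lower number from compound 2 to compound 3 (0.48 log units; beyond the scatter), shows that removing the 5-chloro-1-benzothiophen-3-yl group brings the compound back to a measurable value, although the true size of this step stays unknown. Compound 2 stands at a limit of the assay and not a number: the limit of > 100000 nM in this assay, at which 1 of the 3 values shown sits. The comparison between the two small groups is new and shows that this position on a saturated chain carbon bound to a sulfur also separates them, with a 3.4-fold higher number from compound 1 to compound 3 (0.53 log units; beyond the scatter), so that cyclopropyl in compound 1 keeps the lowest number of the three compounds.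

What the compounds shown leave open is whether the chlorine or the benzothiophenyl group itself weighs against compound 2, a question that the unchlorinated benzothiophenyl group or a plain phenyl group could address. They also leave open whether the gap between compound 1 and compound 3 follows from the ring of cyclopropyl or the double bond of vinyl, which an ethyl group or a longer saturated chain at the same place could begin to separate.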